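The source may hold more compounds than are shown below. What is called first, only, known or untested is meant among the compounds shown, and "the series" means these compounds.

Working notes on the series. In a toxicity assay on THP-1 cells (Homo sapiens) for inhibition (on this read-out higher numbers stand for lower toxicity in this test and lower numbers for higher toxicity in this test), compound 1 (`O=C(Nc1ncc(-c2ccccc2)o1)c1ccc(Cl)cc1`) gives 10000 nM and compound 2 (`Cc1ccc(C(=O)Nc2ncc(-c3ccccc3)o2)cc1`) gives 26000 nM. Compound 2 therefore holds the higher of the two numbers, so it is the less toxic of the pair in this assay.

The next structure is compound 3 (`O=C(Nc1ncc(-c2ccccc2)o1)c1ccc(F)cc1`), with this change from compound 2: fluoro in place of methyl on an aromatic carbon. In words, this is fluoro in place of methyl on an aromatic carbon, or 4-methylphenyl to 4-fluorophenyl.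

Among the measured compounds shown here, only one measured step bears on this change: a 2.6-fold higher number from compound 1 to compound 2 (0.41 log units; beyond the scatter). It is modest and concerns the same ring carbon, with methyl entering in place of chloro. Leaving methyl for fluoro might therefore lower the number, with compound 1 at 10000 nM as the only reference point. For the measured compounds named here, no fluoro compound has been measured yet, and a single step is thin evidence, so only a small shift is expected. The estimated step is a 1.4-fold lower number from compound 2 to compound 3 (0.16 log units; within the scatter), which is expected to fall within the scatter or close to it. The expected value for compound 3 is 18000 nM, with an estimated range of 8000 nM to 40000 nM.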

Compound 3, half-maximal cytotoxic concentration: 17000 nM
The estimate for compound 3 lay 1.1-fold (0.02 log units) above the measured number; the range from low to high includes it.
By their numbers in this assay, from the lowest: compounds 1, 3 and 2 (each within the scatter of the next, the first and the last beyond it).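

Fluoro on this aromatic carbon, para to a large group, gives a 1.5-fold lower number from compound 2 to compound 3 (0.18 log units; within the scatter) in place of methyl and a 1.7-fold higher number from compound 1 to compound 3 (0.23 log units; within the scatter) in place of chloro, so in this assay compound 3 cannot be told apart from either of the other two compounds. Among the compounds shown here, the earlier pair showed only a separation, a 2.6-fold higher number from compound 1 to compound 2 (0.41 log units; beyond the scatter), whereas a third single-atom group at the same carbon now gives a value within the scatter of both, leaving compound 1 and compound 2 as the only pair that stands apart. No measurement at hand bears on what lies behind these numbers.

Going by these compounds, the three compounds cover only methyl and two halogens at this one carbon, so it remains open whether the plain unsubstituted ring, a methoxy group, an amine or a carboxylic acid would stay within this narrow span or leave it. Also open, on these data alone, is whether the same groups would read the same way on the other phenyl ring of the shared core, which is unchanged across all three compounds.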